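Benzyl for trimethoxyphenyl on the amidine nitrogen of the series

The compounds below may be only part of what the source reports. "The series", "measured", "known", "first", "only" and "open" are said of these compounds alone.

Three members of the series have been run in a functional assay on DU-145 cells (Homo sapiens) for cytotoxicity, read by MTT assay, with a stated time of 48 h; on this read-out higher numbers stand for weaker inhibition and lower numbers for stronger inhibition. Compound 1 `Cc1ccc(S(=O)(=O)/N=C(/CCNC2=CC(=O)c3ccccc3C2=O)Nc2ccccc2[N+](=O)[O-])cc1` gives 7590 nM. Compound 2 `COc1ccc(N/C(CCNC2=CC(=O)c3ccccc3C2=O)=N\S(=O)(=O)c2ccc(C)cc2)c(OC)c1` gives 67300 nM. Compound 3 `COc1cc(N/C(CCNC2=CC(=O)c3ccccc3C2=O)=N\S(=O)(=O)c2ccc(C)cc2)cc(OC)c1OC` gives 9330 nM. Compound 4 `Cc1ccc(S(=O)(=O)/N=C(/CCNC2=CC(=O)c3ccccc3C2=O)NCc2ccccc2)cc1` is not yet measured.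

On these numbers compound 3 stands second highest of three: its nearest neighbour is compound 1, and the two are within the scatter of each other, as a 1.2-fold higher number from compound 1 to compound 3 (0.09 log units; within the scatter) shows; the furthest is compound 2, with a 7.2-fold lower number from compound 2 to compound 3 (0.86 log units; beyond the scatter).

The change from compound 3 to compound 4 is benzyl in place of 3,4,5-trimethoxyphenyl on an amine nitrogen.

Every measured step in this set changes the group on that same amine nitrogen, so all three bear on the question, though none of them swaps an aryl group for a benzyl. The step of an 8.9-fold higher number from compound 1 to compound 2 (0.95 log units; beyond the scatter) and the step of a 7.2-fold lower number from compound 2 to compound 3 (0.86 log units; beyond the scatter) are modest and beyond the scatter, while a 1.2-fold higher number from compound 1 to compound 3 (0.09 log units; within the scatter) lies within it. The change to compound 4 thus sits in a region the measured steps have not covered, and on what is known a step of modest size in either direction, or none beyond the scatter, is possible in this assay.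

For compound 4 the expected value is 9000 nM, with a range from 2500 nM to 35000 nM. The step this estimate implies, a 1.0-fold lower number from compound 3 to compound 4 (0.02 log units; within the scatter), is expected to stay within the scatter.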

Compound 4, half-maximal inhibitory concentration: 9120 nM
Beside the measured number, compound 4's estimate is 1.0-fold (0.01 log units) below it; the range from low to high includes it.
By their numbers in this assay, from the lowest: compounds 1, 4 and 3 (each within the scatter of the next); then compound 2.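

Compound 4 is the first member shown with benzyl rather than a substituted phenyl on the amine nitrogen, and in this assay it reads as (a 1.0-fold lower number from compound 3 to compound 4 (0.01 log units; within the scatter)) against the 3,4,5-trimethoxyphenyl group and as (a 1.2-fold higher number from compound 1 to compound 4 (0.08 log units; within the scatter)) against the 2-nitrophenyl group. Compounds 1, 3 and 4 therefore form a group within the scatter of one another despite their different substituents on this nitrogen, while compound 2 alone stands apart, as the remaining comparison (a 7.4-fold lower number from compound 2 to compound 4 (0.87 log units; beyond the scatter)) confirms, so the high number belongs to the 2,4-dimethoxyphenyl compound rather than to the aryl compounds as a class. No measurement on hand accounts for this flat reading or for the separate place of compound 2.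

As far as these compounds go, it remains open whether a longer chain such as phenethyl, or a cyclohexylmethyl group with no aromatic ring, would stay in the same range on this amine nitrogen. Also open, from the compounds shown here alone, is whether a phenyl carrying a single methoxy group would fall with compound 2 or with compound 3, which would show how narrowly the high number of compound 2 depends on its substitution.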